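The source may hold more compounds than are shown below. What is called first, only, known or untested is meant among the compounds shown, and "the series" means these compounds.

Measured in a functional assay on aorta (Rattus norvegicus, strain Wistar); a lower number here means a stronger inhibitor, a higher number a weaker inhibitor:
compound 1 `Cc1ccc2c(c1)N(C1=CCCC1=O)CC(C)(C)S2`: 933 nM
compound 2 `CC(=O)Nc1ccc2c(c1)N(C1=CCCC1=O)CC(C)(C)S2`: 6610 nM
compound 3 `CC1CN(C2=CCCC2=O)c2cc(C(F)(F)F)ccc2S1`: 8.32 nM

Of these three, compound 2 carries the highest number in this assay. Compound 1 lies nearest to it and compound 3 furthest away. The next compound to consider is compound 4 `CCc1ccc2c(c1)N(C1=CCCC1=O)CC(C)(C)S2`, which differs from compound 2 as follows: ethyl in place of acetamido on an aromatic carbon. Put briefly, compound 4 carries ethyl where compound 2 carries acetamido.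

Among the measured compounds shown here, one measured step bears on this change: a 7.1-fold higher number from compound 1 to compound 2 (0.85 log units; beyond the scatter), with acetamido in place of methyl. Read in reverse, it points to a lower number once acetamido leaves. For the measured compounds named here, no measured step covers ethyl in place of methyl, so that part remains open. Compound 3 differs in more than one place and offers no direct guide. The value of compound 1, 933 nM, is therefore the closest reference. The expected change is an 8.3-fold lower number from compound 2 to compound 4 (0.92 log units; beyond the scatter), similar in size to the measured step and beyond the scatter. Compound 4 is estimated at 800 nM, with an expected range of 250 nM to 2500 nM.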

Compound 4, half-maximal inhibitory concentration: 155 nM
Beside the measured number, compound 4's estimate is 5.2-fold (0.71 log units) above it, outside the stated range (below it).
By their numbers in this assay, from the lowest: compound 3; then compound 4; then compound 1; then compound 2.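

On this aromatic carbon, the series in this assay tolerates ethyl far better than acetamido, with a 43-fold lower number from compound 2 to compound 4 (1.63 log units; beyond the scatter) as the largest step read so far at this position. The alkyl group itself also matters, since methyl in place of hydrogen on the saturated chain carbon bound to the aromatic carbon gives a 6.0-fold lower number from compound 1 to compound 4 (0.78 log units; beyond the scatter) and so separates ethyl from methyl beyond the scatter. No supporting measurement accounts for either step.

On these data alone, whether a longer chain such as propyl would extend the shift seen from compound 1 to compound 4 remains open, as does how an amine on this carbon would compare with acetamido. Trifluoromethyl cannot be compared directly with ethyl, as compound 3 differs from compound 4 in more than one place.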